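Replacing the hydroxypropyl chain with methyl in the series

This account rests on a few compounds, and the source may have more. Where it says the series, first, only, none or still open, it means among the compounds named here.

In a functional assay on KB cells (Homo sapiens) for antiproliferative activity, read by sulforhodamine B assay, with a stated time of 48 h (on this read-out higher numbers stand for weaker inhibition of growth and lower numbers for stronger inhibition of growth), compound 2 `COc1ccc(N(C)c2nc(NCCCO)c3ccccc3n2)cc1` gives 24800 nM and compound 1 `CNc1nc(Nc2ccc(OC)cc2)nc2ccccc12` gives 14800 nM. Among the measured compounds shown here, these two numbers lie within the usual scatter of each other, so compound 2 does not stand apart from the only other measured member of the series.

The change under consideration leads to compound 3 `CNc1nc(N(C)c2ccc(OC)cc2)nc2ccccc12` and is hydrogen in place of 2-hydroxyethyl on a saturated chain carbon bound to a nitrogen on an aromatic ring. It is hydrogen in place of 2-hydroxyethyl on a saturated chain carbon bound to a nitrogen on an aromatic ring, which also reads as 3-hydroxypropyl to methyl, or (3-hydroxypropyl)amino to methylamino.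

For the measured compounds named here, no measured pair isolates this change, so the expectation rests on little. Compound 1, at 14800 nM, carries the same methylamino group as compound 3, yet it offers only a loose guide since the two differ elsewhere. A moderate move towards a lower number in this assay is expected, possibly beyond the scatter, though no change at all remains plausible. The estimated size is a 4.1-fold lower number from compound 2 to compound 3 (0.62 log units; beyond the scatter). The expected value for compound 3 is 6000 nM, with an estimated range of 800 nM to 30000 nM.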

Compound 3, concentration for 50% growth inhibition: 18700 nM
The estimate for compound 3 lay 3.1-fold (0.49 log units) below the measured number; low and high end bracket the measured number.
By their numbers in this assay, from the lowest: compounds 1, 3 and 2 (each within the scatter of the next).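

In this assay, the pair of compound 2 and compound 3 now isolates the change from (3-hydroxypropyl)amino to methylamino, and the step stays within the scatter (a 1.3-fold lower number from compound 2 to compound 3 (0.12 log units; within the scatter)), so on this read-out the 3-hydroxypropyl chain can give way to methyl without a measurable shift. The pair of compound 1 and compound 3 isolates a second change, methyl in place of hydrogen on a nitrogen on an aromatic ring, and this step also stays within the scatter (a 1.3-fold higher number from compound 1 to compound 3 (0.10 log units; within the scatter)). Neither single change therefore separates the compounds in this assay, and no measurement at hand offers an explanation for this.

The compounds shown leave open whether a terminal amine or a carboxylic acid on the chain, or a longer chain such as n-hexyl in place of the 3-hydroxypropyl, would move the number beyond the scatter. Also open, going by these compounds, is whether ethyl in place of methyl on the nitrogen on the aromatic ring would give a step that can be told from the scatter.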